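Styryl hydroxamic acids: from compound 1 to compound 3

A few compounds are considered here, and "the series" means these few. Any claim that something is new, unique, unknown or untested is made for them only; others in the source may bear on it.

compound 1 `COc1ccccc1-c1cc(/C=C/c2ccc(C(=O)NO)cc2)ccn1`: 6350 nM
compound 2 `O=C(NO)c1ccc(/C=C/c2ccnc(-c3ccc(C(F)(F)F)cc3)c2)cc1`: > 10000 nM (a limit of the assay)

Among the compounds with values here, in a functional assay on MGC-803 cells (Homo sapiens) for antiproliferative activity, read by CellTiter-Glo, with a stated time of 72 h (on this read-out higher numbers stand for weaker inhibition and lower numbers for stronger inhibition), compound 1 gives 6350 nM, the only actual number so far. Compound 2 gives > 10000 nM, which is a limit and not a number.

The next compound is compound 3 `Cc1ccc(-c2cc(/C=C/c3ccc(C(=O)NO)cc3)ccn2)c(F)c1`. It carries 2-fluoro-4-methylphenyl in place of 2-methoxyphenyl on an aromatic carbon, next to the ring nitrogen of the core of compound 1 (2-fluoro-4-methylphenyl in place of 2-methoxyphenyl on an aromatic carbon).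

Within the data shown here, no measured pair isolates a change at a single place, so the data give no direct guide to the size of this step. In this assay a step within the usual scatter, with no firm direction, is therefore expected. The expected change is a 1.1-fold lower number from compound 1 to compound 3 (0.02 log units; within the scatter). A reading that is only a limit also remains possible for compound 3. The estimated value for compound 3 is 6000 nM, with an expected range from 2000 nM to 15000 nM.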

Compound 3, half-maximal inhibitory concentration: 770 nM
Beside the measured number, compound 3's estimate is 7.8-fold (0.89 log units) above it, outside the stated range (below it).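

In this assay, within the data shown here, the exchange of 2-methoxyphenyl for 2-fluoro-4-methylphenyl on the aromatic carbon next to the ring nitrogen gives an 8.2-fold lower number from compound 1 to compound 3 (0.92 log units; beyond the scatter), the first step that can be read at a single place. The two groups match in heavy-atom count and in their six-membered aromatic ring of carbon only, so the position responds to a change in what the ring carries, not to a change in the counted size of the group; the entering group also lacks the hydrogen-bond acceptor counted in the leaving one. The only other reading for an aryl group at this position is a limit and not a number: the limit of > 10000 nM in this assay, at which 1 of the 3 values shown sits.

On these data alone, the step combines the loss of methoxy with the arrival of both fluorine and methyl, so the share of each remains open, and plain 2-fluorophenyl or 4-methylphenyl would separate them. Also open, as far as these compounds go, is how the position treats a group of another kind on that aryl ring, such as an amine or a carboxylic acid, and whether the step holds in other cell lines.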